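From a Propenamide Arm to a Biphenyl Amide

A few compounds are considered here, and "the series" means these few. Any claim that something is new, unique, unknown or untested is made for them only; others in the source may bear on it.

Three compounds have been measured in a functional assay on A-375 cells (Homo sapiens) for inhibition, read by MTT assay, with a stated time of 120 h; a lower number here means a stronger inhibitor, a higher number a weaker inhibitor:

Compound 1, `CC(NC(=O)C#Cc1ccc(NC(=O)Nc2cc(C(F)(F)F)ccc2Cl)cc1)c1ccccc1`, gives 30500 nM.
Compound 2, `O=C(/C=C/c1ccc(NC(=O)Nc2ccc(Cl)c(C(F)(F)F)c2)cc1)NC1CCC1`, gives 15400 nM.
Compound 3, `CC(NC(=O)c1ccc(-c2ccc(NC(=O)Nc3cc(C(F)(F)F)ccc3Cl)cc2)cc1)c1ccccc1`, gives 16900 nM.

Compound 2 holds the lowest of the three numbers, but the gaps are small: compound 3 sits within the usual scatter, and even compound 1, the furthest away, remains inside it. The three compounds therefore cannot be ranked against one another on these data; all of them are weak inhibitors in this assay.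

Compound 4, `CNC(=O)c1cccc(-c2ccc(NC(=O)Nc3ccc(Cl)c(C(F)(F)F)c3)cc2)c1`, has not yet been measured. It is derived from compound 2 by one change: 3-(methylcarbamoyl)phenyl in place of 2-(cyclobutylcarbamoyl)ethenyl on an aromatic carbon. The urea and the chloro- and trifluoromethyl-bearing ring are untouched; only the amide-carrying arm on the other side of the shared core is rebuilt. Compound 3, which also carries a biphenyl with an amide on its outer ring, gives 16900 nM, close to what compound 2 gives, 15400 nM. Among the compounds with values here, no measured pair shows this exact change, so the size of the step is uncertain; the expectation is a step of a 1.2-fold higher number from compound 2 to compound 4 (0.07 log units; within the scatter), small and not clearly beyond the scatter. Compound 4 is accordingly estimated at about 18000 nM, within a range of 7000 nM to 45000 nM.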

Compound 4, half-maximal inhibitory concentration: 46500 nM
Compound 4: the middle estimate sits 2.6-fold (0.41 log units) below what was measured; the measured number lies above the stated range.
By their numbers in this assay, from the lowest: compounds 2, 3, 1 and 4 (each within the scatter of the next, the first and the last beyond it).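

In this assay, within the data shown here, 3-(methylcarbamoyl)phenyl in place of 2-(cyclobutylcarbamoyl)ethenyl gives the first single-change comparison in this set, with a 3.0-fold higher number from compound 2 to compound 4 (0.48 log units; beyond the scatter), a modest step but one that lies beyond the scatter. It shows that this aromatic carbon, para to a large group, is not indifferent to what it carries, since the number moves while the urea and the chloro- and trifluoromethyl-bearing ring stay untouched and both arms have the same counts of hydrogen-bond donors and acceptors. No measurement shown here accounts for the step.

The change replaces the ethenyl link with a six-membered aromatic ring and the cyclobutyl group on the amide nitrogen with a methyl group in one move, so the compounds shown do not tell how much of the step belongs to each part. Also open, going by these compounds, is how this position would respond to a carboxylic acid or a primary amine in place of the methylcarbamoyl group on the outer ring.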